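Swapping Chloro for Methoxy on the Benzyl Ether

A few compounds are considered here, and "the series" means these few. Any claim that something is new, unique, unknown or untested is made for them only; others in the source may bear on it.

Compound 1 `FC(F)(F)c1ccc(CN2CCN(Cc3cc(-c4ccc(OCc5ccccc5Cl)cc4)on3)CC2)cc1` was tested in a functional assay on Huh-7 cells (Homo sapiens) for antiproliferative activity, read by sulforhodamine B assay, with a stated time of 72 h (on this read-out higher numbers stand for weaker inhibition and lower numbers for stronger inhibition), where compound 1 gives 1000 nM. Among the measured compounds shown here, of the two numbers measured so far, this is the lower one. The nearest comparison is compound 2 `N#Cc1ccccc1COc1ccc(-c2cc(CN3CCN(Cc4ccc(C(F)(F)F)cc4)CC3)no2)cc1`, and in this assay compound 2 gives 5000 nM. These two differ only by cyano in place of chloro on an aromatic carbon, and the step of a 5.0-fold higher number from compound 1 to compound 2 (0.70 log units; beyond the scatter) shows that removing the chloro in favour of cyano weakens inhibition.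

Compound 3 `COc1ccccc1COc1ccc(-c2cc(CN3CCN(Cc4ccc(C(F)(F)F)cc4)CC3)no2)cc1` is not yet measured. It differs from compound 1 in one place: methoxy in place of chloro on an aromatic carbon. So the chloro is once more exchanged, this time for methoxy. For the measured compounds named here, only the step from compound 1 to compound 2 speaks to such an exchange; it was modest yet beyond the scatter. Another replacement of the chloro on the same aromatic carbon is therefore expected to weaken inhibition as well, though the size for a different group is uncertain. For compound 3 the expected step is a 2.5-fold higher number from compound 1 to compound 3 (0.40 log units; beyond the scatter). Compound 3 is estimated at 2500 nM, within a range from 1000 nM to 7000 nM.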

Compound 3, half-maximal inhibitory concentration: 900 nM
For compound 3 the middle estimate is 2.8-fold (0.44 log units) above the measured one, and the stated range ends above it.
By their numbers in this assay, from the lowest: compounds 3 and 1 (each within the scatter of the next); then compound 2.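

In this assay, methoxy in place of chloro on this aromatic carbon gives a step within the scatter (a 1.1-fold lower number from compound 1 to compound 3 (0.05 log units; within the scatter)), so these two groups cannot be told apart here. The earlier pair showed only that one replacement of the chloro, cyano, weakens inhibition; this result shows that replacing the chloro does not by itself carry that cost, and methoxy in place of cyano restores inhibition by a step beyond the scatter (a 5.6-fold lower number from compound 2 to compound 3 (0.74 log units; beyond the scatter)). Among these three compounds, then, the cyano compound stands apart while the chloro and methoxy compounds read alike, and no measurement on hand accounts for this.

Going by these compounds, whether a fluoro, a methyl, a hydroxyl or an amine on the same aromatic carbon would read like chloro and methoxy or like cyano remains open, as does the effect of a longer chain such as ethoxy in place of the methoxy. On these data alone, all three compounds also share the trifluoromethyl group, so it is unknown whether the same comparison would hold with a different group there.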